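Triazole thioethers with a phthalimide core: an ester replaces a ketone

The compounds below may be only part of what the source reports. "The series", "measured", "known", "first", "only" and "open" are said of these compounds alone.

Measured compounds:
compound 1, `C#CCSc1nnc(CC)n1N1C(=O)c2ccccc2C1=O`, > 200000 nM
compound 2, `CCc1nnc(SCc2ccccc2)n1N1C(=O)c2ccccc2C1=O`, > 200000 nM
compound 3, `CCc1nnc(SCC(=O)c2ccc(C)cc2)n1N1C(=O)c2ccccc2C1=O`, > 200000 nM

In a functional assay on HepG2 cells (Homo sapiens) for cytotoxicity, read by MTT assay, with a stated time of 48 h (a lower number here means a stronger inhibitor, a higher number a weaker inhibitor), compound 1 gives > 200000 nM, which is a limit of the assay and not a number. In this assay compound 2 gives > 200000 nM, again a limit. In this assay compound 3 gives > 200000 nM, also a limit. Compound 3 therefore stands on no number at all; it sits at the limit of > 200000 nM in this assay, at which 3 of the 3 values shown sit, together with the two other measured compounds.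

Compound 4, `CCOC(=O)CSc1nnc(CC)n1N1C(=O)c2ccccc2C1=O`, is not yet measured. It differs from compound 3 by ethoxy in place of 4-methylphenyl on a carbonyl carbon. The measured steps that bear on it are the changes at the saturated chain carbon bound to sulfur: a step that the two limits leave unreadable from compound 1 to compound 2, a step that the two limits leave unreadable from compound 1 to compound 3 and a step that the two limits leave unreadable from compound 2 to compound 3. None of them gives a readable size, since all three values are limits. No direction can be taken from them. The account therefore expects compound 4 to remain at the limit as well, with the step of a number no higher from compound 3 to compound 4 (the limit leaves the size open) estimated as none beyond the scatter. Compound 4 is thus estimated at 200000 nM, within a range from 100000 nM to 400000 nM, most probably reported again only as a limit.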

Compound 4, half-maximal inhibitory concentration: > 200000 nM
Compound 4: no number, only a limit; the forecaster's own chance of this, stated with the estimate: 85%; the middle value sits exactly at the limit.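

Compound 4 also ends at a limit of the assay, as compounds 1, 2 and 3 do, so no step among these four compounds can be read: the limit of > 200000 nM in this assay, at which 4 of the 4 values shown sit.

The compounds shown leave open whether any group on the saturated chain carbon bound to a sulfur would give a readable number at all.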